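The source may hold more compounds than are shown below. What is called first, only, known or untested is meant among the compounds shown, and "the series" means these compounds.

Working notes on the series, read in an ADME assay on cells (Hepatocyte, Homo sapiens) for pharmacokinetics (on this read-out higher numbers stand for fast clearance and lower numbers for slow clearance), throughout. Compound 1 (`Cc1cc(C)c2cc(C(=O)NC3CN(c4cc(Cl)ncc4Cl)C3)ccc2n1`) gives 18.6 mL/min/kg and compound 2 (`Cc1cc(C)c2cc(C(=O)NC3CN(c4ccnc(F)c4F)C3)ccc2n1`) gives 18.1 mL/min/kg on the same shared core, so compound 2 stands level with compound 1 within the scatter.

The next compound is compound 3 (`COc1cc(N2CC(NC(=O)c3ccc4nc(C)cc(C)c4c3)C2)c(Cl)cn1`), which has 5-chloro-2-methoxypyridin-4-yl in place of 2,3-difluoropyridin-4-yl on an amine nitrogen in a ring.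

Going by the values given here, one measured step bears on this change, since it alters the group at the same place (a 1.0-fold lower number from compound 1 to compound 2 (0.01 log units; within the scatter)). That step lies within the scatter. Among the compounds with values here, it is thin evidence, as no measured compound carries a methoxy group, so that part of the change is untested. No step beyond the scatter is therefore expected in this assay, and no direction is favoured. The estimated step is small (a 1.0-fold higher number from compound 2 to compound 3 (0.02 log units; within the scatter)).

For compound 3 the expected clearance is about 19 mL/min/kg with an estimated range of 11 mL/min/kg to 32 mL/min/kg for the measurement.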

Compound 3, clearance: 17.5 mL/min/kg
Compound 3: the middle estimate sits 1.1-fold (0.04 log units) above what was measured; measured number inside the range.
By their numbers in this assay, from the lowest: compounds 3, 2 and 1 (each within the scatter of the next).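

In this assay, the methoxy group, untested until now, brings no step beyond the scatter, either with both substituents of the pyridine changed (a 1.0-fold lower number from compound 2 to compound 3 (0.01 log units; within the scatter)) or with methoxy in place of chloro on an aromatic carbon alone (a 1.1-fold lower number from compound 1 to compound 3 (0.03 log units; within the scatter)). The second of these steps is the cleaner reading, as it isolates a single exchange on the ring, and it extends the earlier halogen-only comparison to a group with an oxygen and a further hydrogen-bond acceptor. On an amine nitrogen in a ring, the 2,5-dichloropyridin-4-yl, 2,3-difluoropyridin-4-yl and 5-chloro-2-methoxypyridin-4-yl groups thus stand level on this read-out, and no measured evidence is available to explain that.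

On these data alone, whether this level holds for a different kind of substituent, such as an amine, a carboxylic acid or a longer chain in place of the methoxy, remains open. Also open is whether a change elsewhere on the shared core would move the clearance, as the compounds shown differ only at this one place.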